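The source may report more compounds than this note shows. Statements on the series, on what has been measured and on what is new or still open speak of the compounds shown alone.

In a functional assay on PC-3 cells (Homo sapiens) for inhibition, read by sulforhodamine B assay, with a stated time of 48 h, tested at 50 uM (on this read-out lower numbers stand for less inhibition of growth and higher numbers for more inhibition of growth at the one concentration tested), compound 1 `CCCCOc1ccc([C@@H]2CC(=O)c3cc(CC=C(C)C)c(OC)cc3O2)cc1` gives 48% and compound 2 `COc1cc2c(cc1CC=C(C)C)C(=O)C[C@@H](c1ccc(Oc3ccccc3)cc1)O2` gives 53%, so compound 2 stands level with compound 1 within the scatter. Compound 3 `COc1cc2c(cc1CC=C(C)C)C(=O)C[C@@H](c1ccc(Oc3ccc(Br)cc3)cc1)O2` differs from compound 2 by one change, (bromo in place of hydrogen on an aromatic carbon), which is bromo in place of hydrogen on an aromatic carbon. Among the compounds with values here, the one measured step, a number 5 percentage points higher from compound 1 to compound 2 (within the scatter), is phenyl in place of butyl on an oxygen on an aromatic ring. It involves no bromo and stays within the scatter, so no step beyond the scatter is expected in this assay. The expected step is a number 2 percentage points higher from compound 2 to compound 3 (within the scatter). The estimate for compound 3 is 55%, with an expected range from 40% to 70%.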

Compound 3, percent growth inhibition at one concentration: 55%
Compound 3: the middle estimate sits on the measured number at the digits printed, and the stated range covers the measured number.
By their numbers in this assay, from the lowest: compounds 1, 2 and 3 (each within the scatter of the next).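

In this assay, within the data shown here, bromo in place of hydrogen, turning phenoxy into 4-bromophenoxy, gives a number 2 percentage points higher from compound 2 to compound 3 (within the scatter) and so adds the first evidence on substitution of this aromatic ring, where a single bromine leaves the read-out level. Measured against the butyl group, 4-bromophenyl gives a number 7 percentage points higher from compound 1 to compound 3 (within the scatter) and so also stays level, leaving the three compounds without an order. Nothing measured here explains this flat result.

Going by these compounds, whether an amine or a carboxylic acid at this same place would move the number beyond the scatter stays open. So does the effect of chloro or methoxy in place of bromo.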